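Cytotoxicity limits in an oxalamide series with aryl variation

The source may report more compounds than this note shows. Statements on the series, on what has been measured and on what is new or still open speak of the compounds shown alone.

Measured so far in an ADME assay on TZM-b1 cells (Homo sapiens) for cytotoxicity, read by XTT assay, with a stated time of 3 days; a lower number here means that less compound is tolerated, a higher number that more compound is tolerated:
compound 1 `Cc1ccc(NC(=O)C(=O)NC(c2nc(C)c(CCO)s2)C2CCCCN2)cc1F` gives > 85000 nM, a limit of the assay.
compound 2 `CC(=O)c1ccc(NC(=O)C(=O)NC(c2nc(C)c(CO)s2)C2CCCCN2)cc1` gives > 86000 nM, a limit of the assay.
compound 3 `Cc1nc(C(NC(=O)C(=O)Nc2ccc(F)c(Cl)c2)C2CCCCN2)sc1CCO` gives > 75800 nM, a limit of the assay.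

Compound 3 stands at the limit of > 75800 nM in this assay, at which 1 of the 3 values shown sits; the other two values sit at the limit of > 85000 nM in this assay, at which 1 of the 3 values shown sits, and (the limit of > 86000 nM in this assay, at which 1 of the 3 values shown sits), so every number shown in this assay is a limit, and none of the three compounds can be ordered against another. For the measured compounds named here, the one step that can be formed, a step that the two limits leave unreadable from compound 1 to compound 3, is therefore unreadable in size and direction.

Compound 4 `CC(=O)c1ccc(NC(=O)C(=O)NC(c2nc(C)c(CCO)s2)C2CCCCN2)cc1` differs from compound 3 by 4-acetylphenyl in place of 3-chloro-4-fluorophenyl on an amide-type nitrogen. Going by the values given here, no measured step puts a number on this change. Compound 2 already carries the 4-acetylphenyl group and sits at a limit in this assay, which gives no sign that this aryl group brings measurable cytotoxicity within the tested range.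

Compound 4 is therefore expected to remain at a limit, with a step that the limit leaves unreadable from compound 3 to compound 4 expected to be no change beyond the scatter. The estimate for compound 4 is 85000 nM, within 40000 nM to 120000 nM.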

Compound 4, half-maximal cytotoxic concentration: > 77300 nM
Compound 4: no number, only a limit; the forecaster's own chance of this, stated with the estimate: 90%; the middle value lies beyond the limit too.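

In this assay compound 4 gives > 77300 nM, a limit of the assay. Its steps from compound 1, compound 2 and compound 3 cannot be read. The compounds shown leave open at what concentration any of them becomes cytotoxic, and whether the aryl groups differ at all.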